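Swapping the Aryl Amide Cap on a Flavonol Scaffold

A few compounds are considered here, and "the series" means these few. Any claim that something is new, unique, unknown or untested is made for them only; others in the source may bear on it.

Measured compounds:
- compound 1 `COc1cccc(C(=O)Nc2cccc(-c3oc4cc(-c5ccc(F)cc5)ccc4c(=O)c3O)c2)c1`: 5650 nM
- compound 2 `Cc1cc(C(=O)Nc2cccc(-c3oc4cc(-c5ccc(F)cc5)ccc4c(=O)c3O)c2)ccc1F`: 18900 nM

In a functional assay on HeLa cells (Homo sapiens) for antiproliferative activity, read by CCK-8 assay, with a stated time of 72 h (a higher number here means a weaker inhibitor, a lower number a stronger inhibitor), compound 1 gives 5650 nM, the lowest of the two numbers. Compound 2, which carries 4-fluoro-3-methylphenyl in place of 3-methoxyphenyl on the carbonyl carbon, shows a weaker result: a 3.3-fold higher number from compound 1 to compound 2 (0.52 log units; beyond the scatter). Compound 3 `O=C(Nc1cccc(-c2oc3cc(-c4ccc(F)cc4)ccc3c(=O)c2O)c1)c1ccc(Cl)nc1` is not yet measured. It differs from compound 1 by 6-chloropyridin-3-yl in place of 3-methoxyphenyl on a carbonyl carbon. Among the compounds with values here, the only step that bears on this change is the one from compound 1 to compound 2, which replaced the same group on the same carbonyl carbon and moved the number modestly. A step of comparable size is therefore expected here, more likely towards a higher number, as a 1.6-fold higher number from compound 1 to compound 3 (0.20 log units; within the scatter). Compound 3 is thus estimated at 9000 nM, with a range from 3000 nM to 30000 nM.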

Compound 3, half-maximal inhibitory concentration: 4080 nM
Compound 3: middle estimate off by 2.2-fold (0.34 log units), on the high side; the measured number falls inside the stated range.
By their numbers in this assay, from the lowest: compounds 3 and 1 (each within the scatter of the next); then compound 2.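

Replacing 3-methoxyphenyl with 6-chloropyridin-3-yl on the carbonyl carbon gives a 1.4-fold lower number from compound 1 to compound 3 (0.14 log units; within the scatter) and so shows that an aromatic ring with one hetero atom can stand at this position without a change beyond the scatter. Set against the 4-fluoro-3-methylphenyl cap, the same group gives a 4.6-fold lower number from compound 2 to compound 3 (0.67 log units; beyond the scatter) and so shows that replacing 3-methoxyphenyl need not raise the number. Nothing available explains either step. The compounds shown leave open how the ring nitrogen and the chlorine each contribute, since they always appear together here. They also leave open how an unsubstituted pyridin-3-yl, a morpholine or a carboxylic acid would read on this carbonyl carbon.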